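From a Chlorofuran to an Oxazole on a Shared Core

The source may hold more compounds than are shown below. What is called first, only, known or untested is meant among the compounds shown, and "the series" means these compounds.

Two compounds, compound 1 `Nc1nc(-c2ccc(Cl)o2)nc2sc(CN3CCCCCC3)cc12` and compound 2 `Nc1nc(-c2ccc(Cl)o2)nc2sc(CN3CC=CCC3)cc12`, share a core and differ only in the ring carried on the saturated chain carbon. In an assay on CHO-K1 cells for antagonist activity at adenosine receptor A1 (Homo sapiens), read by a beta-galactosidase reporter, with stated times of 15 min and 6 h (a lower number here means a stronger inhibitor, a higher number a weaker inhibitor), compound 1 gives 1420 nM, while compound 2 gives 190 nM; the difference amounts to a 7.5-fold lower number from compound 1 to compound 2 (0.87 log units; beyond the scatter). Compound 2 thus stands lowest of the two numbers. Compound 3 `Nc1nc(-c2cocn2)nc2sc(CN3CC=CCC3)cc12` keeps the ring of compound 2 and instead alters the aromatic group on the core: 1,3-oxazol-4-yl in place of 5-chlorofuran-2-yl on an aromatic carbon. Going by the values given here, no measured step bears on this position, since the single step from compound 1 to compound 2 concerns a different part of the molecule, so the data give no guide to direction or size here. On that footing compound 3 is expected to show a modest weakening, a 3.2-fold higher number from compound 2 to compound 3 (0.50 log units; beyond the scatter), in this assay. The estimate for compound 3 is 600 nM, with a range from 150 nM to 2500 nM.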

Compound 3, inhibition constant: 2960 nM
Compound 3: the middle estimate sits 4.9-fold (0.69 log units) below what was measured, outside the stated range (above it).
By their numbers in this assay, from the lowest: compound 2; then compound 1; then compound 3.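

The aromatic group on the shared core proves to be a sensitive position in this assay: with the ring on the saturated chain carbon held constant, putting 1,3-oxazol-4-yl in place of 5-chlorofuran-2-yl gives a 16-fold higher number from compound 2 to compound 3 (1.19 log units; beyond the scatter). Going by these compounds alone, the only earlier step, a 7.5-fold lower number from compound 1 to compound 2 (0.87 log units; beyond the scatter), concerned the ring on the chain carbon, so this is the first reading of a change on the aromatic carbon between two ring nitrogen atoms. No evidence is available that accounts for this step.

This single change alters the ring and removes the chlorine together, so the compounds shown cannot separate the two, and it remains open how a plain furan-2-yl group would read here. Also open, from the compounds shown here alone, is whether 1,3-oxazol-4-yl would produce a step of similar size alongside the seven-membered ring of compound 1.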